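Trimming the aryl ketone: methoxy to hydrogen

The compounds below may be only part of what the source reports. "The series", "measured", "known", "first", "only" and "open" are said of these compounds alone.

Three measured compounds share one core and differ only in the aryl group on the carbonyl carbon. In a functional assay on MDA-MB-468 cells (Homo sapiens) for inhibition, read by sulforhodamine B assay, with a stated time of 48 h (on this read-out lower numbers stand for stronger inhibition of growth and higher numbers for weaker inhibition of growth), compound 1 `COc1cc(-c2cc(/C=C/C(=O)c3ccc(N)cc3)[nH]n2)cc(OC)c1OC` gives 1010 nM, compound 2 `COc1cc(-c2cc(/C=C/C(=O)c3ccc(Cl)c(Cl)c3)[nH]n2)cc(OC)c1OC` gives 1980 nM, and compound 3 `COc1ccc(C(=O)/C=C/c2cc(-c3cc(OC)c(OC)c(OC)c3)n[nH]2)cc1OC` gives 750 nM. Compound 3 carries the lowest number of the three, but the step of a 1.3-fold lower number from compound 1 to compound 3 (0.13 log units; within the scatter) lies within the scatter, and only a 2.6-fold lower number from compound 2 to compound 3 (0.42 log units; beyond the scatter) is a modest step beyond it; a 2.0-fold higher number from compound 1 to compound 2 (0.29 log units; within the scatter) is within it as well.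

Compound 4 `COc1ccc(C(=O)/C=C/c2cc(-c3cc(OC)c(OC)c(OC)c3)n[nH]2)cc1` is not yet measured. Relative to compound 3 it carries hydrogen in place of methoxy on an aromatic carbon, ortho to a methoxy group and meta to a large group. Going by the values given here, no measured step removes a single methoxy from this ring; the three steps recorded so far each exchange the whole aryl group on the carbonyl carbon and move the number by at most a modest amount. The change to compound 4 is confined to one group on that ring, so in this assay a step no larger than the scatter is expected, a 1.3-fold higher number from compound 3 to compound 4 (0.12 log units; within the scatter), with no firm direction. The estimate for compound 4 is 1000 nM, within 400 nM to 2500 nM.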

Compound 4, concentration for 50% growth inhibition: 1290 nM
Estimate against measurement, compound 4: 1.3-fold (0.11 log units) below; measured number inside the range.
By their numbers in this assay, from the lowest: compounds 3, 1, 4 and 2 (each within the scatter of the next, the first and the last beyond it).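

Within this assay, this is the first step that changes a single group on the aryl ketone rather than exchanging the whole aryl group: taking away the methoxy ortho to a methoxy group and meta to a large group gives (a 1.7-fold higher number from compound 3 to compound 4 (0.24 log units; within the scatter)), so the change from 3,4-dimethoxyphenyl to 4-methoxyphenyl is not resolved from the scatter. Going by these compounds alone, the 4-methoxyphenyl compound also stays within the scatter of the two other aryl ketones (a 1.5-fold lower number from compound 2 to compound 4 (0.19 log units; within the scatter); a 1.3-fold higher number from compound 1 to compound 4 (0.11 log units; within the scatter)), so the one step beyond the scatter in this set remains that between the 3,4-dichlorophenyl and 3,4-dimethoxyphenyl compounds (a 2.6-fold lower number from compound 2 to compound 3 (0.42 log units; beyond the scatter)). Nothing available accounts for these small steps, and no cause can be assigned to them.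

Still open, from the compounds shown here alone, is whether a hydroxyl or an ethoxy group at this place would move the number beyond the scatter. Also open, going by these compounds, is whether an unsubstituted phenyl on the carbonyl carbon, with no methoxy at all, would stay within the scatter of compound 4.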